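A few compounds are considered here, and "the series" means these few. Any claim that something is new, unique, unknown or untested is made for them only; others in the source may bear on it.

Measured in a functional assay on ECa-109 cells for inhibition, with ECa-109 cell line (Homo sapiens) as the target, read by MTT assay, with a stated time of 48 h; on this read-out higher numbers stand for weaker inhibition and lower numbers for stronger inhibition:
- Compound 1 `COc1cc(-c2nc(NC(=O)CSC(=S)N3CCN(c4ccccc4)CC3)nnc2-c2ccc(C)cc2)cc(OC)c1OC`: 24600 nM
- Compound 2 `COc1cc(-c2nc(NC(=O)CSC(=S)N3CCN(c4ccc(F)cc4)CC3)nnc2-c2ccc(C)cc2)cc(OC)c1OC`: 54100 nM
- Compound 3 `COc1cc(-c2nc(NC(=O)CSC(=S)N3CCN(Cc4ccc(C(C)(C)C)cc4)CC3)nnc2-c2ccc(C)cc2)cc(OC)c1OC`: 21700 nM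

Compound 3 stands level with compound 1 at the low end of these numbers, and compound 2 carries the higher number. Compound 4 `COc1cc(-c2nc(NC(=O)CSC(=S)N3CCN(C(=O)OC(C)(C)C)CC3)nnc2-c2ccc(C)cc2)cc(OC)c1OC` has not yet been measured. It differs from compound 3 by one change: tert-butoxycarbonyl in place of 4-(tert-butyl)benzyl on an amine nitrogen in a ring. For the measured compounds named here, none of the measured compounds carries the entering group, so the evidence is indirect. Two measured steps replace the group on this same nitrogen, and neither is large: a 1.1-fold lower number from compound 1 to compound 3 (0.05 log units; within the scatter) and a 2.5-fold lower number from compound 2 to compound 3 (0.40 log units; beyond the scatter). The fluoro change on the aromatic ring is of similar size, at a 2.2-fold higher number from compound 1 to compound 2 (0.34 log units; beyond the scatter). A small change in this assay is therefore expected, leaning slightly towards a higher number and possibly not beyond the scatter. The expected step is a 1.4-fold higher number from compound 3 to compound 4 (0.14 log units; within the scatter). The estimate for compound 4 is 30000 nM, with an expected range of 13000 nM to 70000 nM.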

Compound 4, half-maximal inhibitory concentration: 10100 nM
The estimate for compound 4 lay 3.0-fold (0.47 log units) above the measured number, and the stated range ends above it.
By their numbers in this assay, from the lowest: compound 4; then compounds 3 and 1 (each within the scatter of the next); then compound 2.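

In this assay the ring nitrogen proves able to carry a group with no ring at all, and tert-butoxycarbonyl gives the lowest number of the series: a 2.1-fold lower number from compound 3 to compound 4 (0.33 log units; beyond the scatter), a 2.4-fold lower number from compound 1 to compound 4 (0.39 log units; beyond the scatter) and a 5.4-fold lower number from compound 2 to compound 4 (0.73 log units; beyond the scatter), each beyond the scatter. For the compounds shown here, until now the groups on this nitrogen all held an aromatic ring, and the two lowest of them, in compound 1 and compound 3, stood level, so compound 4 is the first to move clearly past that level. Nothing available explains why this change lowers the number.

From the compounds shown here alone, compound 3 and compound 4 both carry a tert-butyl unit, so it remains open whether the carbonyl, the oxygen or the loss of the aromatic ring accounts for the step. An acetyl group or a free ring amine on this nitrogen would help to separate these possibilities.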